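Cyclopropylcarbonyl for propanoyl: series note

A few compounds are considered here, and "the series" means these few. Any claim that something is new, unique, unknown or untested is made for them only; others in the source may bear on it.

Three compounds have been run in an assay on Sf9 cells for inhibition of inhibitor of nuclear factor kappa-B kinase subunit epsilon (Homo sapiens), read by ADP-Glo, with a stated time of 60 min; on this read-out higher numbers stand for weaker inhibition and lower numbers for stronger inhibition. Compound 1 `Cc1[nH]nc(N)c1-c1cccc(Cl)c1` gives 93400 nM. Compound 2 `Cc1[nH]nc(N)c1-c1ccc(Br)cc1` returns only a limit of the assay, > 100000 nM. Compound 3 `CCC(=O)n1nc(C)c(-c2ccc(Cl)c(Cl)c2)c1N` likewise returns only a limit of the assay, > 100000 nM. No number for compound 3 is therefore known, and it cannot be placed against compound 1 beyond the fact that it stands at the limit. Two of the three values shown sit at that limit (the limit of > 100000 nM in this assay, at which 2 of the 3 values shown sit).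

Compound 4 `Cc1nn(C(=O)C2CC2)c(N)c1-c1ccc(Cl)c(Cl)c1` differs from compound 3 in one place: cyclopropyl in place of ethyl on a carbonyl carbon. For the measured compounds named here, no measured pair shows this exchange, so nothing about its size or direction is known from the data. The step expected from this exchange is none beyond the scatter, a number no higher from compound 3 to compound 4 (the limit leaves the size open). Compound 4 is estimated at 100000 nM, with a range from 30000 nM to 300000 nM, and this assay is expected most likely to report only a limit for compound 4 once more.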

Compound 4, half-maximal inhibitory concentration: > 100000 nM
Compound 4 was reported as a limit (the forecaster's own chance of this, stated with the estimate: 75%); the middle value lies on the limit itself.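

Compound 3 and compound 4 both return only a limit of the assay in this assay, so no step can be read between them: the limit of > 100000 nM in this assay, at which 3 of the 4 values shown sit.

On these data alone, whether the change from propanoyl to cyclopropylcarbonyl alters inhibition at all, and in which direction, remains open.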